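The source may report more compounds than this note shows. Statements on the series, on what has been measured and on what is new or still open speak of the compounds shown alone.

Notes on the series. Compound 1 `C=CCn1c(=O)c(CCO)c(-c2ccccc2Cl)c2cc(Cl)ccc21` in an ADME assay on HepG2 2.2.15 cells (Homo sapiens) for cytotoxicity (a lower number here means that less compound is tolerated, a higher number that more compound is tolerated), gives 23000 nM. Compound 2 `CC(=O)NCC(=O)OCCc1c(-c2ccccc2Cl)c2cc(Cl)ccc2[nH]c1=O` in this assay gives 110000 nM, the higher of the two numbers, and its gap to compound 1 lies beyond the scatter. Compound 3 `O=C(/C=C/c1cccc(C(F)(F)F)c1)OCCc1c(-c2ccccc2Cl)c2cc(Cl)ccc2[nH]c1=O` awaits measurement in this assay. It differs from compound 2 by 2-(3-(trifluoromethyl)phenyl)ethenyl in place of acetamidomethyl on a carbonyl carbon. Going by the values given here, no measured pair shows this change, so the step is unknown. A downward step beyond the scatter is expected, a 3.7-fold lower number from compound 2 to compound 3 (0.56 log units; beyond the scatter). Compound 3 is expected to give 30000 nM in this assay, with a range from 8000 nM to 100000 nM.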

Compound 3, half-maximal cytotoxic concentration: > 1400000 nM
Compound 3: no number, only a limit; the forecaster's own chance of this, stated with the estimate: 10%; at least 46-fold (1.66 log units) between middle value and limit.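

On a carbonyl carbon, 2-(3-(trifluoromethyl)phenyl)ethenyl in place of acetamidomethyl gives, in this assay, an at least 12-fold higher number from compound 2 to compound 3 (1.10 log units; beyond the scatter). This place therefore tolerates a group carrying an aromatic ring, and the change raises the number rather than lowering it. For compound 3 the result is a limit and not a number: the limit of > 1400000 nM in this assay, at which 1 of the 3 values shown sits.

The compounds shown do not separate the part played by the trifluoromethyl group from that of the ring or the ethenyl unit. Also open, going by these compounds, is how an unsubstituted phenyl, an amine or a carboxylic acid would read at this place.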